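The source may report more compounds than this note shows. Statements on the series, on what has been measured and on what is new or still open speak of the compounds shown alone.

Measured in a functional assay on HL-60 cells (Homo sapiens) for cytotoxicity, read by CellTiter-Blue, with a stated time of 48 h; on this read-out lower numbers stand for stronger inhibition and higher numbers for weaker inhibition:
Compound 1 `COc1cc(OC)cc(-c2ccc3c(c2)C(CC(=O)OCC2CC2)C(C(=O)OCC2CC2)=C(N)O3)c1`: 6700 nM
Compound 2 `CCOC(=O)CC1C(C(=O)OCC)=C(N)Oc2ccc(-c3ccccc3F)cc21`: 73000 nM

Compound 2 holds the higher of the two numbers, and compound 1 lies lower, beyond the scatter. Compound 3 `CCOC(=O)CC1C(C(=O)OCC)=C(N)Oc2ccc(-c3cc(F)cc(F)c3)cc21` has not yet been measured. It carries 3,5-difluorophenyl in place of 2-fluorophenyl on an aromatic carbon. Going by the values given here, the two measured compounds differ in more than one place, so no measured pair isolates a change of this kind, and the expectation remains loose. In this assay, a modest move toward a lower number is expected, and it may not exceed the scatter. The expected change is a 1.6-fold lower number from compound 2 to compound 3 (0.21 log units; within the scatter). The estimated value for compound 3 is 45000 nM, with an expected range of 14000 nM to 110000 nM.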

Compound 3, half-maximal inhibitory concentration: 35900 nM
Beside the measured number, compound 3's estimate is 1.3-fold (0.10 log units) above it; the measured number falls inside the stated range.
By their numbers in this assay, from the lowest: compound 1; then compound 3; then compound 2.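

In this assay, going by these compounds alone, 3,5-difluorophenyl in place of 2-fluorophenyl on the aromatic carbon gives a 2.0-fold lower number from compound 2 to compound 3 (0.31 log units; beyond the scatter), the first change that can be read at a single place. The step is modest, and compound 3 at 35900 nM shows that this position accepts a second fluorine and a new fluorine pattern without the number rising. Nothing measured here bears on what lies behind the step.

On these data alone, whether the step follows the added fluorine or its new placement stays open, since the change alters both at once. Also open, as far as these compounds go, is how an aminophenyl group at this position, or a carboxylic acid in place of the ethyl esters, would read in this assay, and compound 1 differs from both other compounds in more than one place, so its 6700 nM cannot be assigned to any single group.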